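This account rests on a few compounds, and the source may have more. Where it says the series, first, only, none or still open, it means among the compounds named here.

Of the compounds shown here, three of a shared core have been measured in a functional assay on Raji cells (Homo sapiens) for antiproliferative activity, read by MTT assay, with a stated time of 48 h; on this read-out higher numbers stand for weaker inhibition and lower numbers for stronger inhibition. Compound 1, `CN(C)CCn1c(N)c(-c2nc3ccccc3[nH]2)c2nc(C#N)c(C#N)nc21`, gives 8320 nM. Compound 2, `CCN(CC)CCn1c(N)c(-c2nc3ccccc3[nH]2)c2nc(C#N)c(C#N)nc21`, gives 8950 nM. The single change between them is diethylamino in place of dimethylamino on a saturated chain carbon, two bonds along the chain from an aromatic nitrogen

The step it made is a 1.1-fold higher number from compound 1 to compound 2 (0.03 log units; within the scatter), so the two numbers cannot be told apart.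

Compound 3, `CN(C)CCCn1c(N)c(-c2nc3cc(Cl)ccc3[nH]2)c2nc(C#N)c(C#N)nc21`, gives 3110 nM, the lowest of the three numbers. Its core is not the same as that of compound 1, and the difference between the two cores is not broken down here; only the two values can be compared, and the number for compound 3 lies well away from that of compound 1.

Compound 4, `CCN(CC)CCCn1c(N)c(-c2nc3cc(Cl)ccc3[nH]2)c2nc(C#N)c(C#N)nc21`, has not yet been measured. It differs from compound 3 in one place: diethylamino in place of dimethylamino on a saturated chain carbon, three bonds along the chain from an aromatic nitrogen

Within the data shown here, this is the same kind of change as the one from compound 1 to compound 2, though not the same: there the place was two bonds along the chain from an aromatic nitrogen, here it is three bonds along the chain from an aromatic nitrogen. Among the measured compounds shown here, on the one precedent, compound 4 is expected to sit close to compound 3, with a step of about a 1.1-fold higher number from compound 3 to compound 4 (0.04 log units; within the scatter), because the same kind of change gave a 1.1-fold higher number from compound 1 to compound 2 (0.03 log units; within the scatter). The expected value for compound 4 in this assay is therefore 3400 nM, estimated to fall between 1600 nM and 7000 nM.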

Compound 4, half-maximal inhibitory concentration: 1620 nM
Beside the measured number, compound 4's estimate is 2.1-fold (0.32 log units) above it, and the stated range covers the measured number.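

In this assay, putting diethylamino in place of dimethylamino on the second core gives a 1.9-fold lower number from compound 3 to compound 4 (0.28 log units; within the scatter), so the numbers for these two compounds cannot be told apart, and the step agrees with the one seen earlier on the first core: the same change on two cores in this assay, a 1.1-fold higher number (0.03 log units; within the scatter) from compound 1 to compound 2 and a 1.9-fold lower number (0.28 log units; within the scatter) from compound 3 to compound 4, 2.1-fold (0.31 log units) apart, within the scatter of two such steps

This shows that, on the two cores tested here, the swap from 2-(dimethylamino)ethyl to 2-(diethylamino)ethyl and the swap from 3-(dimethylamino)propyl to 3-(diethylamino)propyl each leave the number within the usual scatter of repeated measurements, and the change can be said to carry over between these two cores as far as this read-out can tell. Among these compounds, it does not show that the change is without effect on every core, since there is only one pair on each core and a small real effect could remain hidden within the scatter.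

Still open, as far as these compounds go, is whether a ring amine such as pyrrolidine or morpholine at the end of the chain, or a longer chain such as 4-(diethylamino)butyl, would give a step beyond the scatter. Also open, from the compounds shown here alone, is whether the same swap would hold on a third core carrying a different group on the benzimidazole-bearing part of the structure.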